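Solubility of a sulfonamide analogue in the pyridine-fused urea series

The source may hold more compounds than are shown below. What is called first, only, known or untested is meant among the compounds shown, and "the series" means these compounds.

Of the compounds shown here, three sharing one core have been measured in a physicochemical assay for solubility, in phosphate buffer, with a stated time of 24 h, at pH 7.4, tested at 100 uM; a lower number here means a less soluble compound, a higher number a more soluble compound. Compound 1 `O=C(NCc1ccc(S(=O)(=O)c2cc(F)cc(F)c2)cc1)N1Cc2ccncc2C1` gives 16000 nM. Compound 2 `CCCn1cc(S(=O)(=O)c2ccc(CNC(=O)N3Cc4ccncc4C3)cc2)cn1` gives 105000 nM, and compound 3 `CC(C)n1cc(S(=O)(=O)c2ccc(CNC(=O)N3Cc4ccncc4C3)cc2)cn1` gives 192000 nM. Compound 2 thus stands second highest of the three: the step of a 1.8-fold higher number from compound 2 to compound 3 (0.26 log units; within the scatter) is within the scatter, whereas the step of a 6.6-fold higher number from compound 1 to compound 2 (0.82 log units; beyond the scatter) and the step of a 12-fold higher number from compound 1 to compound 3 (1.08 log units; beyond the scatter) are both beyond it.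

Compound 4 `O=C(NCc1ccc(S(=O)(=O)N2CCC(N3CCCC3)CC2)cc1)N1Cc2ccncc2C1` differs from compound 2 in one place: 4-(pyrrolidin-1-yl)piperidin-1-yl in place of 1-propyl-1H-pyrazol-4-yl on a sulfonyl sulfur. For the measured compounds named here, none of the measured steps covers this change; the two steps that lie beyond the scatter, from compound 1, concern a pyrazole replacing 3,5-difluorophenyl, and the step between the two pyrazoles is within the scatter. Going by the values given here, with no direct precedent, the number for compound 4 in this assay is expected to sit near that of compound 2 or somewhat higher, the step of a 1.7-fold higher number from compound 2 to compound 4 (0.23 log units; within the scatter) being the estimate. Compound 4 is therefore estimated at 180000 nM, with a range from 70000 nM to 450000 nM.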

Compound 4, solubility: 6200 nM
For compound 4 the middle estimate is 29-fold (1.46 log units) above the measured one; the measured number lies below the stated range.
By their numbers in this assay, from the lowest: compound 4; then compound 1; then compounds 2 and 3 (each within the scatter of the next).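

For the compounds shown here, at the sulfonyl sulfur, the earlier compounds showed only rises in this assay on going from 3,5-difluorophenyl to a pyrazole, whereas 4-(pyrrolidin-1-yl)piperidin-1-yl brings a large fall from both pyrazoles (a 17-fold lower number from compound 2 to compound 4 (1.23 log units; beyond the scatter); a 31-fold lower number from compound 3 to compound 4 (1.49 log units; beyond the scatter)). The number also falls relative to the 3,5-difluorophenyl compound (a 2.6-fold lower number from compound 1 to compound 4 (0.41 log units; beyond the scatter)), so compound 4 stands lowest of the four and this position spans a wider range, in both directions, than the first three compounds revealed. Nothing given here bears on the reason for this fall.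

The compounds shown leave open whether the fall belongs to the piperidine ring or to the pyrrolidine ring carried on it. They also leave open where a morpholin-4-yl group or a dimethylamino group on the sulfonyl sulfur would fall in this assay.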